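A few compounds are considered here, and "the series" means these few. Any claim that something is new, unique, unknown or untested is made for them only; others in the source may bear on it.

Measured compounds in this series:

- compound 1 `COc1ccccc1NC(=O)CCc1nc(Cc2ccc(NC(C)=O)cc2)no1` — 87.7%
- compound 2 `COc1ccc(NC(=O)CCc2nc(Cc3ccc(NC(C)=O)cc3)no2)cc1OC` — 95.9%
- compound 3 `CC(=O)Nc1ccc(Cc2noc(CCC(=O)Nc3ccc(C(F)(F)F)cc3)n2)cc1` — 37%

All three were run in a functional assay on the whole organism (strain C57BL/6) for inhibition, with Mus musculus as the target, read by paw edema, with stated times of 1 h and 4 h, at a dose of 100 mg/kg by the oral route; on this read-out lower numbers stand for less inhibition and higher numbers for more inhibition at the one dose given (going by the name of the read-out). Compound 1 stands second highest of the three numbers. Its nearest neighbour is compound 2, and the step of a number 8.2 percentage points higher from compound 1 to compound 2 (within the scatter) is within the scatter, so no order between compound 1 and compound 2 can be read from these values. The furthest is compound 3, reached by the step of a number 50.7 percentage points lower from compound 1 to compound 3 (beyond the scatter), which is beyond the scatter and large. The step of a number 58.9 percentage points lower from compound 2 to compound 3 (beyond the scatter) is likewise large.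

Compound 4 `C#Cc1cccc(NC(=O)CCc2nc(Cc3ccc(NC(C)=O)cc3)no2)c1` has not yet been measured. It differs from compound 1 as follows: 3-ethynylphenyl in place of 2-methoxyphenyl on an amide-type nitrogen.

Going by the values given here, the only steps that bear on this change are those that also alter the group on the amide-type nitrogen. The step from compound 1 to compound 2, keeping a methoxy-bearing phenyl, did not move the read-out beyond the scatter. The steps to compound 3, where the methoxy-bearing phenyl is exchanged for 4-(trifluoromethyl)phenyl, each cut the read-out by a large margin. Among the compounds with values here, the ethynyl group is, like the trifluoromethyl group, without a hydrogen-bond acceptor, but no measured compound carries a 3-ethynylphenyl here, so the outcome is uncertain. A drop of middling size is expected, smaller than that seen for compound 3, and the estimated step is a number 22.7 percentage points lower from compound 1 to compound 4 (beyond the scatter).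

Compound 4 is therefore estimated at 65%, in a range from 35% to 90%.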

Compound 4, a percentage reported as inhibition, in the whole organism at one dose (the size of the read-out at that dose, not a potency): 84.9%
For compound 4 the middle estimate is 19.9 percentage points below the measured one; the measured number falls inside the stated range.
By their numbers in this assay, from the lowest: compound 3; then compounds 4, 1 and 2 (each within the scatter of the next, the first and the last beyond it).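

In this assay, the 3-ethynylphenyl group has 0 hydrogen-bond acceptors where the 2-methoxyphenyl group has 1, yet a number 2.8 percentage points lower from compound 1 to compound 4 (within the scatter), so a methoxy group on this phenyl is not required for a read-out at the level of compound 1. The low number of compound 3 is thus not shared by every phenyl without methoxy, as a number 47.9 percentage points higher from compound 3 to compound 4 (beyond the scatter) shows, while a number 11 percentage points lower from compound 2 to compound 4 (beyond the scatter) is a modest step and the smaller of the two that lie beyond the scatter here. Nothing at hand explains why these groups on the amide-type nitrogen read as they do.

Whether the low number of compound 3 goes with the trifluoromethyl group itself or with its place on the phenyl stays open, as the trifluoromethyl and ethynyl groups each appear at only one place in the compounds shown. Also open, going by these compounds, is how a phenyl carrying an amine or a carboxylic acid, or a longer alkyl chain in place of the phenyl, would read on the amide-type nitrogen.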